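The compounds below may be only part of what the source reports. "The series", "measured", "known", "first", "only" and "open" are said of these compounds alone.

Measured: compound 1 `COCc1cc(C(C)=O)c(O)cc1OCCCCCCC#N` gives 47%; compound 2 `CCc1cc(C(C)=O)c(O)cc1OCCCC(C)(C)C#N` gives 85%.

In an assay on isolated protein for inhibition of leukotriene B4 receptor 1 (Homo sapiens), tested at 10 uM (on this read-out higher numbers stand for more inhibition at the one concentration tested (going by the name of the read-out) and lower numbers for less inhibition), compound 2 stands highest of the two numbers at 85%; compound 1 lies lower at 47%, a gap beyond the scatter. Compound 3 `CCc1cc(C(C)=O)c(O)cc1OCCCC(C)(C)C(N)=O` is not yet measured. Its change from compound 2: carbamoyl in place of cyano on a saturated chain carbon bound to three saturated chain carbons. Among the measured compounds shown here, no measured pair shows this change, so its size is open; a moderate decrease in this assay seems more likely than a gain, with a wide range. Compound 3 is expected near 60%, between 25% and 90%. The expected step is a number 25 percentage points lower from compound 2 to compound 3 (beyond the scatter).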

Compound 3, a percentage reported as inhibition, at one concentration (the size of the read-out at that concentration, not a potency): 92%
The estimate for compound 3 lay 32 percentage points below the measured number; measured number outside the range, above it.
By their numbers in this assay, from the lowest: compound 1; then compounds 2 and 3 (each within the scatter of the next).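

In this assay, carbamoyl in place of cyano on a saturated chain carbon bound to three saturated chain carbons gives a number 7 percentage points higher from compound 2 to compound 3 (within the scatter). At this position, the two groups therefore read alike, and the hydrogen-bond donor that carbamoyl brings leaves the read-out within the scatter. Nothing on hand accounts for this equivalence.

On these data alone, a carboxylic acid or an amine on this carbon remains open. So does whether the same exchange would read alike on a longer chain.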